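The source may hold more compounds than are shown below. What is called first, only, known or untested is meant among the compounds shown, and "the series" means these compounds.

In a physicochemical assay for solubility (on this read-out higher numbers stand for higher solubility and lower numbers for lower solubility), compound 2, `O=C(Nc1nc(-c2cccc(C(F)(F)F)c2F)cs1)c1cc(Cl)c(N2CCC(C(=O)O)CC2)c(Cl)c1`, gives only a limit, < 10 ug/mL. Compound 1, `O=C(Nc1nc(-c2cccc(C(F)(F)F)c2F)cs1)c1cnc(N2CCCC(C(=O)O)C2)c(Cl)c1`, likewise returns only a limit in this assay, < 10 ug/mL. Compound 3, `O=C(Nc1nc(-c2cccc(C(F)(F)F)c2F)cs1)c1cnc(N2CCC(C(=O)O)CC2)c(Br)c1`, also returns only a limit in this assay, < 10 ug/mL. All three measured values thus sit at the same point, (the limit of < 10 ug/mL in this assay, at which 3 of the 3 values shown sit), so compound 2 cannot be placed higher or lower than its neighbours on the numbers shown; no measured pair differs in a single place, and no step between measured compounds can be read from them.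

The unmeasured compound 4, `O=C(Nc1nc(-c2cccc(C(F)(F)F)c2F)cs1)c1ccc(N2CCC(C(=O)O)CC2)c(Cl)c1`, differs from compound 2 by hydrogen in place of chloro on an aromatic carbon. With every measured value resting at the limit of < 10 ug/mL in this assay, at which 3 of the 3 values shown sit, the data give no measure of how much such a change moves solubility, and any expectation must rest on the change itself rather than on a shown step. The expected step in this assay is an at least 1.2-fold higher number from compound 2 to compound 4 (0.07 log units; that floor lies within the scatter), a modest rise in the direction of higher solubility that may not clear the usual scatter. Compound 4 is therefore estimated at 12 ug/mL, with a range from 4 ug/mL to 35 ug/mL, and a fair chance that this assay again reports only a limit.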

Compound 4, solubility: < 10 ug/mL
Compound 4 ended at the assay's limit; the forecaster's own chance of this, stated with the estimate: 50%; at least 1.2-fold (0.07 log units) between middle value and limit.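

In this assay, going by these compounds alone, compound 4 returned only a limit, as compound 2 did, so no step from compound 2 to compound 4 can be read: the limit of < 10 ug/mL in this assay, at which 4 of the 4 values shown sit. The compounds shown leave open the actual solubility of each compound, and whether hydrogen in place of chloro on an aromatic carbon changes it at all.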